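Hydrazone series: cytotoxicity notes, hydroxy to fluoro exchange

A few compounds are considered here, and "the series" means these few. Any claim that something is new, unique, unknown or untested is made for them only; others in the source may bear on it.

The series shares one core. Compound 1 `COc1ccccc1-c1nnc(-c2ccc(C(=O)N/N=C/c3ccc([N+](=O)[O-])cc3)cc2)o1` in an ADME assay on THP-1 cells (Homo sapiens) for cytotoxicity (on this read-out higher numbers stand for weaker inhibition and lower numbers for stronger inhibition), gives 203000 nM. Compound 2 `COc1ccccc1-c1nnc(-c2ccc(C(=O)N/N=C/c3ccccc3O)cc2)o1` gives in this assay a value of 207000 nM. The step of a 1.0-fold higher number from compound 1 to compound 2 (0.01 log units; within the scatter) exchanges the aryl group on the carbon with a double bond to nitrogen and moves nothing. Compound 2 stands at the top of the two numbers, yet its gap to compound 1 is within the scatter, so the two cannot be ordered. Compound 3 `COc1ccccc1-c1nnc(-c2ccc(C(=O)N/N=C/c3ccccc3F)cc2)o1` differs from compound 2 by fluoro in place of hydroxy on an aromatic carbon. Within the data shown here, the only measured step, a 1.0-fold higher number from compound 1 to compound 2 (0.01 log units; within the scatter), bears on this change in so far as it varies the same aryl group and stays within the scatter; no measured step tests fluoro in place of hydroxy. For compound 3 the expected step is therefore a 1.0-fold lower number from compound 2 to compound 3 (0.01 log units; within the scatter), within the scatter. The estimate for compound 3 in this assay is 200000 nM, with a range from 100000 nM to 400000 nM.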

Compound 3, half-maximal inhibitory concentration: 313000 nM
Beside the measured number, compound 3's estimate is 1.6-fold (0.19 log units) below it, within the range that was stated.
By their numbers in this assay, from the lowest: compounds 1, 2 and 3 (each within the scatter of the next).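

Notes on the exchange: in this assay the direct test of fluoro in place of hydroxy, on an aromatic carbon ortho to a large group, reads a 1.5-fold higher number from compound 2 to compound 3 (0.18 log units; within the scatter) and so stays inside the scatter, even though hydroxy carries a hydrogen-bond donor and acceptor and fluoro is counted with neither. The wider comparison of 2-fluorophenyl with 4-nitrophenyl on the carbon with a double bond to nitrogen reads a 1.5-fold higher number from compound 1 to compound 3 (0.19 log units; within the scatter) for this read-out, so compounds 1, 2 and 3 cannot be ordered. No supporting data bear on this result.

As far as these compounds go, it remains open whether an amine or a carboxylic acid on this aromatic carbon would give a value outside the scatter of these three compounds. The same question stands for a longer chain, such as an ethoxy group, at this place.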